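A few compounds are considered here, and "the series" means these few. Any claim that something is new, unique, unknown or untested is made for them only; others in the source may bear on it.

Measured compounds:
Compound 1 `CCN(c1cccc(-c2ccccc2)c1)c1ccc(C#N)c(Cl)c1`: in a functional assay on PC-3 cells (Homo sapiens) for antiproliferative activity, read by CCK-8 assay, with a stated time of 6 days (a higher number here means a weaker inhibitor, a lower number a stronger inhibitor), compound 1 gives "not determined" (no result reported).
Compound 2 `Cn1nccc1-c1cccc2c1CCCN2c1ccc(C#N)c(C(F)(F)F)c1`: in this assay compound 2 gives 9800 nM.
Compound 3 `CCN(c1ccc(C#N)c(Cl)c1)c1cc(-c2ccccc2)ccc1C`: in this assay compound 3 gives "not determined" (no result reported).

For the measured compounds named here, compound 3 therefore stands without a number in this assay, and compound 1 shares that gap; the only number in the set belongs to compound 2, a weak inhibitor. Compound 4 `CCN(c1ccc(C#N)c(Cl)c1)c1cc(-n2cccn2)ccc1C` has not yet been tested. It differs from compound 3 at one point: 1H-pyrazol-1-yl in place of phenyl on an aromatic carbon. Going by the values given here, no step between measured compounds exists to show what such a change does, and with compound 3 itself unmeasured there is no anchor for a direction. The account can only say that no shift beyond the scatter is expected in either direction. On that thin basis, compound 4 is estimated to fall near 5000 nM, with an expected range from 500 nM to 50000 nM, resting on the weak value shown by compound 2.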

Compound 4, half-maximal inhibitory concentration: 15700 nM
Beside the measured number, compound 4's estimate is 3.1-fold (0.50 log units) below it; measured number inside the range.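

In this assay, for the compounds shown here, compound 3 gives "not determined" (no result reported) and no step to compound 4 can be read from that entry. As far as these compounds go, what replacing phenyl with 1H-pyrazol-1-yl does to this activity stays open. No evidence at hand bears on the result.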